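Nitro in place of methylsulfonyl on the shared core

The source may report more compounds than this note shows. Statements on the series, on what has been measured and on what is new or still open speak of the compounds shown alone.

Compound 1 `C/C(=N\OCC(=O)O)c1ccccc1` carries the shared core with hydrogen on the aromatic carbon in question. In a functional assay on the whole organism for inhibition, with Rattus norvegicus as the target, read by paw edema, with stated times of 1 h and 3 h, at a dose of 50 mg/kg by the oral route (a higher number here means more inhibition at the dose given (going by the name of the read-out), a lower number less inhibition), compound 1 gives < 20%, which is a limit of the assay and not a number. Compound 2 `C/C(=N\OCC(=O)O)c1ccc(O)cc1` has hydroxy in place of hydrogen on an aromatic carbon. In this assay compound 2 gives < 20%, again a limit of the assay. Compound 3 `C/C(=N\OCC(=O)O)c1ccc(S(C)(=O)=O)cc1` has methylsulfonyl in place of hydrogen on an aromatic carbon, and in this assay compound 3 gives 20%. This is the only number shown in the set. The two further values are limits.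

The step of a number no lower from compound 1 to compound 3 (the limit leaves the size open) and the step of a number no lower from compound 2 to compound 3 (the limit leaves the size open) cannot be sized, and the step that the two limits leave unreadable from compound 1 to compound 2 cannot be read at all, because of the limit of < 20% in this assay, at which 2 of the 3 values shown sit.

Compound 4 `C/C(=N\OCC(=O)O)c1ccc([N+](=O)[O-])cc1` has not yet been measured. Its difference from compound 3: nitro in place of methylsulfonyl on an aromatic carbon. Among the compounds with values here, no measured step with a readable size bears on this change, so nothing in the set points in either direction beyond the scatter. The step of no change at the digits printed from compound 3 to compound 4 (within the scatter) is therefore expected to remain within the scatter. Compound 4 is estimated to give 20% in this assay, within 5% to 35%, with a fair chance that only a limit is reported.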

Compound 4, a percentage reported as inhibition, in the whole organism at one dose (the size of the read-out at that dose, not a potency): < 20%
Compound 4 gave a limit, no number (the forecaster's own chance of this, stated with the estimate: 50%); the middle value sits exactly at the limit.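

Nitro in place of methylsulfonyl on this aromatic carbon, para to a group of 8 heavy atoms, gives a number no higher from compound 3 to compound 4 (the limit leaves the size open) in this assay. Methylsulfonyl thus remains the only group at this position in the compounds shown with a numerical reading, although the open size leaves it unknown whether the two groups truly differ. Nitro and methylsulfonyl have the same counts of hydrogen-bond donors and acceptors and no net charge, so matching those counts did not carry a numerical reading over to compound 4, and the other steps to compound 4 cannot be read, with no size available for any new step: the limit of < 20% in this assay, at which 3 of the 4 values shown sit.

The compounds shown leave open whether an amine, a carboxylic acid or a longer chain on this aromatic carbon would move the reading clear of the limit. Within the data shown here, they also leave open how much weight methylsulfonyl deserves, since in this assay compound 3 supplies the single number, 20%, and no second numerical value tests it.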